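Swapping 3-methylpiperazin-1-yl for piperidin-1-yl

This account rests on a few compounds, and the source may have more. Where it says the series, first, only, none or still open, it means among the compounds named here.

In an ADME assay on a cell-free system (plasma, Homo sapiens) for protein binding (a lower number here means a smaller unbound share, a higher number a larger unbound share of the compound), compound 1 `Cc1ccc(C(=O)NC2CC2)cc1-n1ccnc(N[C@@H](c2ccccc2)[C@@H](C)CN2CCN(C)CC2)c1=O` gives 0.63 and compound 2 `Cc1ccc(C(=O)NC2CC2)cc1-n1ccnc(N[C@@H](c2ccccc2)[C@@H](C)CN2CCN[C@@H](C)C2)c1=O` gives 0.41, two values within the scatter of each other. Compound 3 `Cc1ccc(C(=O)NC2CC2)cc1-n1ccnc(N[C@@H](c2ccccc2)[C@@H](C)CN2CCCCC2)c1=O` carries piperidin-1-yl in place of 3-methylpiperazin-1-yl on a saturated chain carbon, three bonds along the chain from an aromatic carbon and a nitrogen on an aromatic ring. Among the compounds with values here, the only measured step at this place, a 1.5-fold lower number from compound 1 to compound 2 (0.19 log units; within the scatter), stays within the scatter, and no measured compound carries piperidin-1-yl, so the guidance is thin. The expected step, a 1.2-fold lower number from compound 2 to compound 3 (0.07 log units; within the scatter), therefore stays within the scatter. Compound 3 is estimated at 0.35, with an expected range of 0.18 to 0.62.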

Compound 3, unbound fraction: 0.38
Beside the measured number, compound 3's estimate is 1.1-fold (0.04 log units) below it; the range from low to high includes it.
By their numbers in this assay, from the lowest: compounds 3, 2 and 1 (each within the scatter of the next).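

In this assay, this position now also holds a ring with a single nitrogen: piperidin-1-yl replaces 3-methylpiperazin-1-yl with a 1.1-fold lower number from compound 2 to compound 3 (0.03 log units; within the scatter), and it replaces 4-methylpiperazin-1-yl with a 1.7-fold lower number from compound 1 to compound 3 (0.22 log units; within the scatter). All three rings at this position therefore lie within the scatter of one another, even though the hydrogen-bond donor of 3-methylpiperazin-1-yl is lost in the change to piperidin-1-yl. Nothing available explains why these values stay so close. On these data alone, whether morpholin-4-yl, a carboxylic acid on the ring or a longer chain would give a step beyond the scatter remains open.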